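This account rests on a few compounds, and the source may have more. Where it says the series, first, only, none or still open, it means among the compounds named here.

Series so far, in a functional assay on M21 cells (Homo sapiens) for inhibition, read by sulforhodamine B assay, with a stated time of 48 h; on this read-out higher numbers stand for weaker inhibition of growth and lower numbers for stronger inhibition of growth:
compound 1 `c1ccc(-c2ccc(NC3=NCCO3)cc2)cc1`: 8800 nM
compound 2 `CC(C)(C)c1ccc(NC2=NCCO2)cc1`: 2400 nM

Compound 2 holds the lower of the two numbers, and so shows the stronger inhibition of growth. The next compound is compound 3 `Cc1ccc(NC2=NCCO2)cc1`, with methyl in place of tert-butyl on an aromatic carbon. Within the data shown here, only one measured step bears on this change: a 3.7-fold lower number from compound 1 to compound 2 (0.56 log units; beyond the scatter), with tert-butyl in place of phenyl. It is modest and beyond the scatter. Among the measured compounds shown here, no measured compound carries methyl, so the direction rests on thin evidence. A modest step to a higher number in this assay is expected, similar in size to the one measured. The estimated change is a 3.8-fold higher number from compound 2 to compound 3 (0.57 log units; beyond the scatter). Compound 3 is expected at 9000 nM, with an estimated range of 3500 nM to 25000 nM.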

Compound 3, concentration for 50% growth inhibition: 22000 nM
For compound 3 the middle estimate is 2.4-fold (0.39 log units) below the measured one; low and high end bracket the measured number.
By their numbers in this assay, from the lowest: compound 2; then compound 1; then compound 3.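

In this assay, the step from tert-butyl to methyl on this aromatic carbon is the largest seen so far in the series (a 9.2-fold higher number from compound 2 to compound 3 (0.96 log units; beyond the scatter)), so the group at this place has more effect on the read-out than the first pair alone showed. Methyl also gives weaker inhibition of growth than phenyl (a 2.5-fold higher number from compound 1 to compound 3 (0.40 log units; beyond the scatter)), which sets the order of the three groups as tert-butyl, phenyl, methyl, from strongest inhibition of growth to weakest. The step from 4 carbons to 1 thus costs more than the exchange of tert-butyl for phenyl.

Open, from the compounds shown here alone, is whether ethyl or isopropyl at the same place would fall between methyl and tert-butyl. Also open, going by these compounds, is how a methoxy group or a carboxylic acid would stand against these three groups, and no measurement at hand gives a reason for the order.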